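The source may report more compounds than this note shows. Statements on the series, on what has been measured and on what is new or still open speak of the compounds shown alone.

Compound 1, `COc1cc(Cl)cc(-c2nn(-c3cccc(NC(=O)Nc4ccc(Cl)c(C(F)(F)F)c4)c3)cc2-c2ccncc2)c1`, gives 78% in a functional assay on RXF 393 cells (Homo sapiens) for inhibition, read by sulforhodamine B assay, with a stated time of 48 h, tested at 1 uM; on this read-out lower numbers stand for a stronger effect and higher numbers for a weaker effect at the one concentration tested. Compound 2, `COc1cc(Cl)cc(-c2nn(-c3cccc(NC(=O)Nc4cccc(C(F)(F)F)c4)c3)cc2-c2ccncc2)c1`, gives 68% in this assay. Among the measured compounds shown here, the only measured step between them, a number 10 percentage points lower from compound 1 to compound 2 (within the scatter), came with hydrogen in place of chloro on an aromatic carbon, so compound 2 stands at the lower of the two numbers recorded, with compound 1 as its only neighbour, and the gap between them lies within the scatter.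

Compound 3, `COc1cc(Cl)cc(-c2nn(-c3cccc(NC(=O)c4cccc(C(F)(F)F)c4)c3)cc2-c2ccncc2)c1`, is the next compound in line. Its change from compound 2 is 3-(trifluoromethyl)phenyl in place of (3-(trifluoromethyl)phenyl)amino on a carbonyl carbon. For the measured compounds named here, no measured step touches this part of the structure: the one step known, the one from compound 1 to compound 2, concerns a different place and was itself within the scatter, so it gives little guidance about what a change at the carbonyl carbon should do. On that basis compound 3 is expected to show a step of a number 2 percentage points higher from compound 2 to compound 3 (within the scatter), not beyond the scatter in either direction. Compound 3 is therefore estimated to give 70% in this assay, with a range from 48% to 92%.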

Compound 3, a percentage reported as activity, at one concentration (the size of the read-out at that concentration, not a potency): 53%
Beside the measured number, compound 3's estimate is 17 percentage points above it; low and high end bracket the measured number.
By their numbers in this assay, from the lowest: compound 3; then compounds 2 and 1 (each within the scatter of the next).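

The carbonyl carbon is a place where the read-out responds: in this assay, putting 3-(trifluoromethyl)phenyl in place of (3-(trifluoromethyl)phenyl)amino gives a number 15 percentage points lower from compound 2 to compound 3 (beyond the scatter), whereas the chloro change seen earlier stayed within the scatter. The wider exchange on the same carbon, 3-(trifluoromethyl)phenyl in place of (4-chloro-3-(trifluoromethyl)phenyl)amino, gives a number 25 percentage points lower from compound 1 to compound 3 (beyond the scatter), so in both pairs the compound without the amino nitrogen and its hydrogen-bond donor has the lower number, which stands for the stronger effect at the one concentration tested. Nothing available here speaks to the cause of these steps.

The compounds shown leave open whether the amino nitrogen itself matters, and a methylene group or an N-methylamino group on the carbonyl carbon would bear on that question. They also leave open whether 4-chloro-3-(trifluoromethyl)phenyl on the carbonyl carbon, in place of the 3-(trifluoromethyl)phenyl of compound 3, would move the number at all, and what a carboxylic acid or a longer chain would do at this place.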